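Replacing methoxymethyl on the chain-bearing core

This account rests on a few compounds, and the source may have more. Where it says the series, first, only, none or still open, it means among the compounds named here.

Among the compounds with values here, compound 1 (`CCCCC/C=C\C/C=C\CCCCCCCC1(O)CC(=O)c2c(O)cc(OCOC)cc2O1`) gives 16100 nM in a functional assay on MDA-MB-231 cells (Homo sapiens) for antiproliferative activity, read by MTT assay (on this read-out lower numbers stand for stronger inhibition and higher numbers for weaker inhibition), the only exact number so far. Compound 2 (`CCCCCCCCCCCCCCCC1(O)CC(=O)c2c(O)cc(OCOC)cc2O1`) gives > 87000 nM, which is a limit. Within the data shown here, the one measured step, an at least 5.4-fold higher number from compound 1 to compound 2 (0.73 log units; beyond the scatter), alters the chain and keeps the methoxymethyl, so it does not bear directly on the next change. Compound 3 (`CCCCC/C=C\C/C=C\CCCCCCCC1(O)CC(=O)c2c(O)cc(O)cc2O1`) has hydrogen in place of methoxymethyl on an oxygen on an aromatic ring. Among the measured compounds shown here, with no measured step at that place, the expectation in this assay rests on compound 1 at 16100 nM, and no step beyond the scatter is expected. The expected step is a 1.2-fold lower number from compound 1 to compound 3 (0.06 log units; within the scatter). For compound 3 the estimated value is 14000 nM, within 5000 nM to 45000 nM.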

Compound 3, half-maximal inhibitory concentration: 6790 nM
Compound 3: middle estimate off by 2.1-fold (0.31 log units), on the high side; measured number inside the range.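

Methoxymethoxy to hydroxy on the aromatic ring is the first change at this place that can be read: in this assay it gives a 2.4-fold lower number from compound 1 to compound 3 (0.37 log units; beyond the scatter). Methoxymethyl is therefore not required for activity on the deca-1,4-dien-1-yl chain, and the free hydroxy is the better of the two groups here. No measured property shown bears on this step.

As far as these compounds go, whether the step carries over to the saturated chain of compound 2 stays open. From the compounds shown here alone, how a methyl ether or an acetate on this oxygen would compare also stays open.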